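The source may hold more compounds than are shown below. What is called first, only, known or untested is meant among the compounds shown, and "the series" means these compounds.

Of the compounds shown here, three built on one shared core have been measured in an ADME assay on the whole organism with Oryza sativa as the target, tested at 10 uM; a higher number here means a weaker effect of the compound at the concentration tested, a lower number a stronger effect. Compound 1, `CC(C)c1ccccc1NC(=O)N[C@H](C)c1ccccc1`, gives 17%. Compound 2, `C[C@@H](NC(=O)Nc1ccccc1C(F)(F)F)c1ccccc1`, gives 54%, and compound 3, `C[C@@H](NC(=O)Nc1ccccc1F)c1ccccc1`, gives 77%. Compound 3 therefore stands highest of the three: the step of a number 23 percentage points higher from compound 2 to compound 3 (beyond the scatter) and the step of a number 60 percentage points higher from compound 1 to compound 3 (beyond the scatter) both lie beyond the scatter, so compound 3 shows the weakest effect of the set.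

Compound 4, `C[C@@H](NC(=O)Nc1ccccc1Cl)c1ccccc1`, differs from compound 3 in a single place: chloro in place of fluoro on an aromatic carbon, on an aromatic carbon of a six-membered aromatic ring of carbon only, ortho to a large group. Within the data shown here, every measured step so far altered the group on this same aromatic carbon: a number 37 percentage points higher from compound 1 to compound 2 (beyond the scatter), a number 60 percentage points higher from compound 1 to compound 3 (beyond the scatter) and a number 23 percentage points higher from compound 2 to compound 3 (beyond the scatter), each beyond the scatter, with fluoro giving the highest number. None of these steps involved chloro, so the data do not fix the direction. Since each change at this carbon has moved the number beyond the scatter, a modest step is expected, estimated as a number 12 percentage points lower from compound 3 to compound 4 (beyond the scatter), most likely downward from the top position held by compound 3. Compound 4 is thus expected to give about 65%, within an estimated range from 42% to 85%.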

Compound 4, a percentage reported as activity, at one concentration (the size of the read-out at that concentration, not a potency): 93%
Compound 4: the middle estimate sits 28 percentage points below what was measured, and the stated range ends below it.
By their numbers in this assay, from the lowest: compound 1; then compound 2; then compound 3; then compound 4.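

In this assay the change to chloro gives a number 16 percentage points higher from compound 3 to compound 4 (beyond the scatter) and so shows that fluoro does not mark the top of the range at this aromatic carbon, ortho to a large group. Set against the other two groups at the same carbon, chloro gives a number 39 percentage points higher from compound 2 to compound 4 (beyond the scatter) and a number 76 percentage points higher from compound 1 to compound 4 (beyond the scatter) and thereby makes compound 4 the compound with the weakest effect of the four, while the two halogens, fluoro and chloro, now hold the two highest numbers and isopropyl still gives the lowest. Nothing available here explains this order of the four groups.

As far as these compounds go, how bromo, a methyl group, a methoxy group or an amine on this same carbon would fall within that order remains open. It is equally unknown whether the order of the four groups would hold if another part of the shared core were changed as well.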